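This account rests on a few compounds, and the source may have more. Where it says the series, first, only, none or still open, it means among the compounds named here.

Compound 1 `O=C1c2ccc(C#Cc3ccccc3)nc2CCN1C1CCCC1` gives 890 nM in an assay on HEK293 cells for displacement of a labelled ligand from metabotropic glutamate receptor 5 (Homo sapiens), with a stated time of 2 h; a higher number here means a weaker inhibitor, a lower number a stronger inhibitor. Compound 2 `Cc1cccc(C#Cc2ccc3c(n2)CCN(C2CCCC2)C3=O)c1` carries one extra methyl and gives 670 nM in this assay, so the step of a 1.3-fold lower number from compound 1 to compound 2 (0.12 log units; within the scatter). Compound 3 `Cc1ccc(C#Cc2ccc3c(n2)CCN(C2CCCC2)C3=O)cc1` carries its methyl at a different spot and gives > 32000 nM in this assay, which is a limit rather than a number (the limit of > 32000 nM in this assay, at which 1 of the 3 values shown sits). Compound 3 therefore stands at the weak end of the three measured compounds, since the step of an at least 35-fold higher number from compound 1 to compound 3 (1.55 log units; beyond the scatter) and the step of an at least 47-fold higher number from compound 2 to compound 3 (1.67 log units; beyond the scatter) are both far beyond the scatter.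

Compound 4 `O=C1c2ccc(C#Cc3ccccc3Cl)nc2CCN1C1CCCC1` has not yet been measured in this assay. It differs from compound 3 in one place: 2-chlorophenyl in place of 4-methylphenyl on a triple-bonded carbon. Both large measured steps arose when the 4-methylphenyl entered, so removing it is expected to reverse much of that loss; a lower number, roughly in the region of compounds 1 and 2 or somewhat above, is expected, with the step of an at least 16-fold lower number from compound 3 to compound 4 (1.20 log units; beyond the scatter). The expected value for compound 4 is 2000 nM, with a likely range from 500 nM to 15000 nM.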

Compound 4, inhibition constant: > 32000 nM
Compound 4: no number, only a limit (the forecaster's own chance of this, stated with the estimate: 20%); middle value at least 16-fold (1.20 log units) away from the limit.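

The weak binding in this assay is not tied to the 4-methylphenyl alone: with the plain phenyl as the starting point, the 2-chlorophenyl brings an at least 35-fold higher number from compound 1 to compound 4 (1.55 log units; beyond the scatter) and, with the 3-methylphenyl as the starting point, the 2-chlorophenyl brings an at least 47-fold higher number from compound 2 to compound 4 (1.67 log units; beyond the scatter) in the same direction. Among the groups shown on the triple-bonded carbon, only the 3-methylphenyl of compound 2 stays within the scatter of the plain phenyl of compound 1, while compound 3 and compound 4 go against any idea that this position accepts added groups freely. The step between compound 3 and compound 4 cannot be read because both are limits, not numbers: the limit of > 32000 nM in this assay, at which 2 of the 4 values shown sit.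

As far as these compounds go, it remains open whether a 2-methylphenyl or a 3-chlorophenyl would behave like the 3-methylphenyl or like the 2-chlorophenyl. From the compounds shown here alone, how much weaker compound 3 and compound 4 truly are also remains unknown.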